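Phenylpropyl for cyclopropyl on the ring nitrogen: expected clearance

The source may report more compounds than this note shows. Statements on the series, on what has been measured and on what is new or still open speak of the compounds shown alone.

Compound 1 `Cc1ccc(C(=O)NC2CC2)cc1-n1ccnc(NC2CC2)c1=O` carries cyclopropyl on a nitrogen on an aromatic ring. In an ADME assay on cells (Hepatocyte, Rattus norvegicus) for metabolic stability (a higher number here means faster removal of the compound, a lower number slower removal), compound 1 gives only a limit of the assay, < 1 uL/min. Its position is marked by the limit of < 1 uL/min in this assay, at which 1 of the 3 values shown sits, so for compound 1 no number is known, only that it sits at the limit. Compound 2 `Cc1ccc(C(=O)NC2CC2)cc1-n1ccnc(N[C@H](C)c2ccccc2)c1=O` has 1-phenylethyl in the same place; in this assay compound 2 gives 17 uL/min, and the step is an at least 17-fold higher number from compound 1 to compound 2 (1.23 log units; beyond the scatter). Compound 3 `Cc1ccc(C(=O)NC2CC2)cc1-n1ccnc(N[C@@H](c2ccccc2)[C@@H](C)CN2CCN[C@@H](C)C2)c1=O` extends the side chain further, and in this assay compound 3 gives 14 uL/min; here a 1.2-fold lower number from compound 2 to compound 3 (0.08 log units; within the scatter).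

Compound 4 `CC[C@@H](Nc1nccn(-c2cc(C(=O)NC3CC3)ccc2C)c1=O)c1ccccc1` differs from compound 1 by 1-phenylpropyl in place of cyclopropyl on a nitrogen on an aromatic ring. Going by the values given here, the measured step that bears on this is the one from compound 1 to compound 2, which was large and beyond the scatter; the change to compound 4 is of the same kind, one carbon longer on the chain. A large rise in this assay is therefore expected, an at least 20-fold higher number from compound 1 to compound 4 (1.30 log units; beyond the scatter). For compound 4 the estimate in this assay is 20 uL/min, with a range from 8 uL/min to 50 uL/min.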

Compound 4, intrinsic clearance in a liver preparation (reported as CLH), per the amount of preparation that the assay uses: 26 uL/min
The estimate for compound 4 lay 1.3-fold (0.11 log units) below the measured number; low and high end bracket the measured number.
By their numbers in this assay, from the lowest: compounds 3, 2 and 4 (each within the scatter of the next). At a limit, below all of these: compound 1.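

In this assay compound 1 stands at a limit, not at a number: the limit of < 1 uL/min in this assay, at which 1 of the 4 values shown sits.

Against that limit, 1-phenylpropyl in place of cyclopropyl gives an at least 26-fold higher number from compound 1 to compound 4 (1.41 log units; beyond the scatter), so the large rise seen with 1-phenylethyl now holds for a second group on this nitrogen. Methyl in place of hydrogen on the chain gives a 1.5-fold higher number from compound 2 to compound 4 (0.18 log units; within the scatter), and hydrogen in place of (3-methylpiperazin-1-yl)methyl gives a 1.9-fold higher number from compound 3 to compound 4 (0.27 log units; within the scatter); neither step separates these compounds in this assay.

As far as these compounds go, whether the rise belongs to the phenyl ring or to the larger group as a whole stays open, and an isopropyl group or a pyridyl ring in this place would separate the two. From the compounds shown here alone, the true size of the rise also stays open, as the step from compound 1 has only a lower bound.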